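This account rests on a few compounds, and the source may have more. Where it says the series, first, only, none or still open, it means among the compounds named here.

Measured so far:
compound 1 `C[C@@H]1CN(c2nc(-c3cnn(C)c3)cnc2C#N)CCN1C(=O)C1CC1` — 39 mL/min/kg
compound 2 `Cn1cc(-c2ncc(C#N)c(N3C[C@@H]4C[C@H]3CN4CC3CC3)n2)cn1` — 158 mL/min/kg

In an ADME assay on microsomes from liver (Rattus norvegicus) for pharmacokinetics (a higher number here means faster removal of the compound, a lower number slower removal), compound 2 stands highest of the two numbers, with compound 1 the nearest at a lower value. Compound 3 `Cn1cc(-c2ncc(C#N)c(N3C[C@@H]4C[C@H]3CN4S(=O)(=O)C3CC3)n2)cn1` is not yet measured. It differs from compound 2 in one place: cyclopropylsulfonyl in place of cyclopropylmethyl on an amine nitrogen in a ring. Among the measured compounds shown here, no measured pair carries this change, so the size of the step is uncertain; a drop beyond the scatter in this assay is expected, since compound 1, the other measured compound, gives 39 mL/min/kg. Compound 3 is therefore estimated at 55 mL/min/kg, with a range from 22 mL/min/kg to 130 mL/min/kg, a step of a 2.9-fold lower number from compound 2 to compound 3 (0.46 log units; beyond the scatter).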

Compound 3, clearance: < 36 mL/min/kg
Compound 3 gave a limit, no number (the forecaster's own chance of this, stated with the estimate: 5%); middle value at least 1.5-fold (0.18 log units) from the limit.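

In this assay, swapping cyclopropylmethyl for cyclopropylsulfonyl on this amine nitrogen gives an at least 4.3-fold lower number from compound 2 to compound 3 (0.64 log units; beyond the scatter), so this one position alone can move clearance beyond the scatter while the rest of compound 2 stays unchanged. The value for compound 3 is a limit, so the step has a known minimum but no known full size: the limit of < 36 mL/min/kg in this assay, at which 1 of the 3 values shown sits.

This single pair cannot show whether the sulfonyl link or the cyclopropyl ring carries the change. From the compounds shown here alone, a methylsulfonyl or acetyl group on the same nitrogen remains open, as does how far clearance would fall with either.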